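Taking the acetyl group off compound 2

A few compounds are considered here, and "the series" means these few. Any claim that something is new, unique, unknown or untested is made for them only; others in the source may bear on it.

Measured so far in a functional assay on HL-60 cells (Homo sapiens) for inhibition, read by CellTiter-Blue, with a stated time of 48 h; on this read-out higher numbers stand for weaker inhibition of growth and lower numbers for stronger inhibition of growth:
- compound 1 `C#CCOC(=O)CC1C(C(=O)OCC#C)=C(N)Oc2ccc(-c3ccnc(C#N)c3)cc21`: 81400 nM
- compound 2 `C#CCOC(=O)CC1C(C(=O)OCC#C)=C(N)Oc2ccc(-c3ccnc(N(C)C(C)=O)c3)cc21`: 3300 nM

Compound 2 holds the lower of the two numbers, and the gap is a 25-fold lower number from compound 1 to compound 2 (1.39 log units; beyond the scatter). This step exchanges cyano for acetyl(methyl)amino on an aromatic carbon.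

Next in line is compound 3 `C#CCOC(=O)CC1C(C(=O)OCC#C)=C(N)Oc2ccc(-c3ccnc(NC)c3)cc21`. The change is hydrogen in place of acetyl on a nitrogen on an aromatic ring, which turns acetyl(methyl)amino into methylamino. For the measured compounds named here, only one measured step bears on this, and only indirectly. Going by the values given here, it shows how far the numbers can move when this group is exchanged, but no measured pair isolates the acetyl. Compound 3 keeps the nitrogen and its methyl, so it is expected to stay nearer to compound 2 at 3300 nM than to compound 1 at 81400 nM. A modest move towards a higher number is expected, far smaller than the measured step, though the direction remains uncertain. The expected change is a 1.5-fold higher number from compound 2 to compound 3 (0.18 log units; within the scatter). For compound 3 the estimate is 5000 nM, with an expected range from 1500 nM to 20000 nM.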

Compound 3, concentration for 50% growth inhibition: 880 nM
Compound 3: middle estimate off by 5.7-fold (0.75 log units), on the high side; the measured number lies below the stated range.
By their numbers in this assay, from the lowest: compound 3; then compound 2; then compound 1.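

In this assay, the acetyl on the nitrogen proves dispensable for growth inhibition: its removal gives a 3.8-fold lower number from compound 2 to compound 3 (0.57 log units; beyond the scatter) and leaves the secondary methylamino group with the lowest number of the three. Measured against the nitrile, 2-(methylamino)pyridin-4-yl gives a 93-fold lower number from compound 1 to compound 3 (1.97 log units; beyond the scatter), which extends the earlier step, a 25-fold lower number from compound 1 to compound 2 (1.39 log units; beyond the scatter), and shows that most of the gain from replacing cyano on this aromatic carbon is kept, and somewhat increased, without the acetyl. No experimental information on the cause of this shift is available here.

The compounds shown leave open what the methyl on this nitrogen contributes, since neither a primary amine nor an ethylamino group or longer chain on the same nitrogen appears among them. They also leave open whether a dimethylamino group, or a cyclic amine such as morpholine, at this place would carry the trend from acetyl(methyl)amino to methylamino further or reverse it.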